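Two Chain Double Bonds, One Drawn Differently

The source may report more compounds than this note shows. Statements on the series, on what has been measured and on what is new or still open speak of the compounds shown alone.

compound 1 `CCCCCCCC/C=C\c1c(C)nc(C)c(/C=C\CCCCCCCC)c1C` gives "not determined" (no result reported)
compound 2 `CCCCCCCC/C=C\c1c(C)c(/C=C\CCCCCCCC)c2[n+](c1C)CCC2` gives 860 nM
compound 3 `CCCCCCCCCCc1c(C)c(CCCCCCCCCC)c2[n+](c1C)CCCC2` gives 400 nM

In a functional assay on OVCAR-3 cells (Homo sapiens) for antiproliferative activity, read by WST assay, with a stated time of 72 h, in the presence of a further agent that is not named here (a higher number here means a weaker inhibitor, a lower number a stronger inhibitor), compound 2 gives 860 nM as the higher of the two numbers, which makes it the weaker inhibitor of the pair. Compound 3 gives 400 nM as the lower number, and this gap lies beyond the usual scatter.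

Compound 4 `CCCCCCCC/C=C\c1c(C)c(/C=C/CCCCCCCC)c(C)[n+]2c1CCC2` has no result yet. Its change from compound 2 is small: the two compounds have the same atoms and bonds and differ only in configuration as drawn: 1 of 2 stereo elements differ; a double bond is drawn Z in compound 2 and E in compound 4. Among the compounds with values here, no measured pair shows what such a change does, so only a modest shift seems likely. The expected step of a 1.1-fold lower number from compound 2 to compound 4 (0.06 log units; within the scatter) is small, within the scatter and without a clear direction. Compound 4 is estimated at 750 nM with 280 nM to 2000 nM as the expected range.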

Compound 4, half-maximal inhibitory concentration: 600 nM
Beside the measured number, compound 4's estimate is 1.3-fold (0.10 log units) above it; the range from low to high includes it.
By their numbers in this assay, from the lowest: compounds 3, 4 and 2 (each within the scatter of the next, the first and the last beyond it).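

In this assay, the step reads a 1.4-fold lower number from compound 2 to compound 4 (0.16 log units; within the scatter), so redrawing one chain double bond from Z to E does not separate these two compounds. Within the data shown here, none of the earlier compounds formed a pair that isolated this change. The comparison is clean on one point: the fact that compounds 2 and 4 differ only in the configuration as drawn

Still open is whether the other chain double bond, drawn Z in both compounds, would give a similar result if it were drawn E. The compounds shown also leave open what a longer chain or a terminal carboxylic acid would do.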